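The compounds below may be only part of what the source reports. "The series", "measured", "known", "first", "only" and "open" are said of these compounds alone.

Measured so far in a functional assay on PANC-1 cells (Homo sapiens) for inhibition, read by MTT assay, with a stated time of 24 h, tested at 10 uM; on this read-out lower numbers stand for less inhibition and higher numbers for more inhibition at the one concentration tested (going by the name of the read-out):
compound 1 `CC(C)=CCOc1cc(=O)n(CCCO)c2c1CC(CC=C(C)C)C(C)(C)C2` gives 7.5%
compound 2 `CC(C)=CCC1Cc2c(OCCCNS(=O)(=O)c3ccc(C(F)(F)F)cc3)cc(=O)n(CCCO)c2CC1(C)C` gives 0%
compound 3 `CC(C)=CCC/C(C)=C/CC1Cc2c(OCC=C(C)C)cc(=O)n(CCCO)c2CC1(C)C` gives 15.9%

Compound 3 stands highest of the three numbers. Its gap to compound 1 is within the scatter, so the two cannot be told apart; its gap to compound 2 is beyond the scatter, and that is the only separation the series shows so far.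

Compound 4 `CC(C)=CCC/C(C)=C/CC1Cc2c(OC(=O)Nc3ccc(Cl)cc3)cc(=O)n(CCCO)c2CC1(C)C` keeps the chain of compound 3 and alters the group on the ring oxygen: (4-chlorophenyl)carbamoyl in place of 3-methylbut-2-en-1-yl on an oxygen on an aromatic ring.

For the measured compounds named here, the one measured step, a number 8.4 percentage points higher from compound 1 to compound 3 (within the scatter), concerns the chain carbon and not the ring oxygen, so it does not bear on this change. Going by the values given here, what is known of the oxygen position comes from compounds 1 and 2, for which no step is computed: compound 1, carrying 3-methylbut-2-en-1-yl on that oxygen, gives 7.5%, while compound 2, carrying another group there, gives 0%. Exchanging the 3-methylbut-2-en-1-yl on the oxygen thus went once with a lower number, and the carbamoyl group entering here is again an exchange of that kind. A step downward, a number 8.9 percentage points lower from compound 3 to compound 4 (within the scatter), is therefore expected, of a size near the edge of the scatter. Compound 4 is estimated at 7%, with a range from 0% to 22%.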

Compound 4, a percentage reported as inhibition, at one concentration (the size of the read-out at that concentration, not a potency): 4.3%
Compound 4: the middle estimate sits 2.7 percentage points above what was measured; the measured number falls inside the stated range.
By their numbers in this assay, from the lowest: compounds 2, 4, 1 and 3 (each within the scatter of the next, the first and the last beyond it).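

In this assay, for the compounds shown here, the exchange at this position gives the first step on the ring oxygen that lies beyond the scatter: a number 11.6 percentage points lower from compound 3 to compound 4 (beyond the scatter), with (4-chlorophenyl)carbamoyl in place of 3-methylbut-2-en-1-yl and the rest of the structure held fixed. Before this, the position was known only from the printed values of compound 1 at 7.5% and compound 2 at 0%, with no computed step, so the lower number on leaving 3-methylbut-2-en-1-yl now rests on a second exchange, one that is modest in size. The change brings in an aromatic ring, a nitrogen, a chlorine and a hydrogen-bond donor all at once, and no measurement on hand accounts for the lower number.

Going by these compounds alone, the single step does not separate these features, so it remains open whether a plain phenylcarbamoyl, without the chlorine, or an acetyl group on the same oxygen would give a similar number. Also open, on these data alone, is how a free hydroxyl or an aminoalkyl chain ending in a simple amine at this position would read against compound 3.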